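A few compounds are considered here, and "the series" means these few. Any claim that something is new, unique, unknown or untested is made for them only; others in the source may bear on it.

Compound 2 `COc1cc(OC)c(OC)cc1/C=C/COC(=O)/C=C/c1ccccc1C(F)(F)F` is measured in a functional assay on the whole organism (strain Kunming) with Mus musculus as the target, with a stated time of 0.5 h, at a dose of 100 mg/kg by the intraperitoneal route (a lower number here means a stronger effect, a higher number a weaker effect of the compound at the dose given), where compound 2 gives 100%. Its nearest neighbour, compound 1 `COc1ccccc1/C=C/C(=O)OC/C=C/c1cc(OC)c(OC)cc1OC`, gives 100% in this assay, and the step of no change at the digits printed from compound 1 to compound 2 (within the scatter). Compound 3 `COc1cc(OC)c(OC)cc1/C=C/COC(=O)/C=C/c1cccc(Br)c1` is not yet measured; it differs from compound 2 by 3-bromophenyl in place of 2-(trifluoromethyl)phenyl on a double-bonded chain carbon bound to a double-bonded chain carbon. Within the data shown here, the only measured step, which also exchanged a group on an aromatic carbon, stayed within the scatter, but no measured step exchanges the ring in this exact way, so some uncertainty remains. Compound 3 is therefore expected to stay near the top of the read-out, with a step of a number 10 percentage points lower from compound 2 to compound 3 (within the scatter). The estimate for compound 3 in this assay is 90%, within a range from 60% to 100%.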

Compound 3, a percentage reported as activity, at one dose (the size of the read-out at that dose, not a potency): 100%
For compound 3 the middle estimate is 10 percentage points below the measured one; the range from low to high includes it.
By their numbers in this assay, from the lowest: compounds 1, 2 and 3 (each within the scatter of the next).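

In this assay, 3-bromophenyl in place of 2-(trifluoromethyl)phenyl gives no change at the digits printed from compound 2 to compound 3 (within the scatter), and 3-bromophenyl in place of 2-methoxyphenyl gives no change at the digits printed from compound 1 to compound 3 (within the scatter). At this position on the double-bonded chain carbon, three different substituted phenyl groups therefore leave the read-out level, including a bromine-bearing group as well as the two earlier ones. Nothing available explains this result.

On these data alone, whether a phenyl ring carrying an amine or a carboxylic acid would move the number remains open. A read-out at one dose also cannot show whether these compounds differ in potency.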